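The source may hold more compounds than are shown below. What is called first, only, known or untested is meant among the compounds shown, and "the series" means these compounds.

Measured compounds:
- compound 1, `CCOC(=O)CO/N=C(/c1ccc(OC)c(OC)c1OC)c1cccc2ccccc12`: 6720 nM
- compound 2, `CCOC(=O)/C=C/CO/N=C(/c1ccc(OC)c(OC)c1OC)c1cccc2ccccc12`: 14000 nM

Both numbers come from a functional assay on A549 cells (Homo sapiens) for inhibition, read by sulforhodamine B assay, with a stated time of 48 h; a higher number here means a weaker inhibitor, a lower number a stronger inhibitor. Compound 2 holds the highest of the two numbers; its nearest neighbour is compound 1, and the step of a 2.1-fold higher number from compound 1 to compound 2 (0.32 log units; beyond the scatter) separates them.

Compound 3, `COc1ccc(/C(=N/OCC(=O)O)c2cccc3ccccc23)c(OC)c1OC`, is not yet measured. Its change from compound 2 is carboxy in place of 2-(ethoxycarbonyl)ethenyl on a saturated chain carbon bound to an oxygen on an unsaturated carbon. For the measured compounds named here, the only measured step that touches the same place is a 2.1-fold higher number from compound 1 to compound 2 (0.32 log units; beyond the scatter), where a longer chain at that position gave a modestly higher number. Compound 3 shortens the chain again, but exchanges the ester for a carboxy group, for which no comparison exists in the series, so the direction of the step cannot be read from the data. The expected step of a 1.1-fold higher number from compound 2 to compound 3 (0.03 log units; within the scatter) is therefore set near zero, with a wide range. Compound 3 is estimated at 15000 nM in this assay, expected between 4000 nM and 60000 nM.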

Compound 3, half-maximal inhibitory concentration: 17200 nM
Beside the measured number, compound 3's estimate is 1.1-fold (0.06 log units) below it; low and high end bracket the measured number.
By their numbers in this assay, from the lowest: compound 1; then compounds 2 and 3 (each within the scatter of the next).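

In this assay, the ethyl ester of compound 1 is now compared directly with its free carboxy counterpart at the same position, and a 2.6-fold higher number from compound 1 to compound 3 (0.41 log units; beyond the scatter) is a modest step in the same direction as a 2.1-fold higher number from compound 1 to compound 2 (0.32 log units; beyond the scatter). Exchanging 2-(ethoxycarbonyl)ethenyl for carboxy gives a 1.2-fold higher number from compound 2 to compound 3 (0.09 log units; within the scatter), so these two quite different groups cannot be told apart in this assay, and among the three compounds only the ethoxycarbonyl group of compound 1 stands apart. Nothing at hand explains these numbers.

Still open, on these data alone, is whether an amide or a methyl ester on this chain carbon would stay near compound 1 at 6720 nM or join the other two compounds. The effect of a longer saturated chain ending in a carboxylic acid, which would separate chain length from the ester, also remains unresolved.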